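This account rests on a few compounds, and the source may have more. Where it says the series, first, only, none or still open, it means among the compounds named here.

Measured compounds in a functional assay on the whole organism for activation, with Mus musculus as the target; on this read-out higher numbers stand for an effect only at larger amounts of compound and lower numbers for an effect already at smaller amounts:
compound 1, `CCCSc1nc(N)c2nc(O)n(Cc3ccccc3)c2n1`: 0.1 mg/kg
compound 2, `CCCCNc1nc(N)c2nc(O)n(Cc3ccccc3)c2n1`: 0.1 mg/kg
compound 3, `Nc1ncnc2c1nc(O)n2Cc1ccccc1`: 30 mg/kg

Compound 3 stands at the highest number of the three in this assay, and both steps that lead to it are large: a 300-fold higher number from compound 1 to compound 3 (2.48 log units; beyond the scatter) and a 300-fold higher number from compound 2 to compound 3 (2.48 log units; beyond the scatter). The two compounds carrying a chain at that aromatic carbon differ from each other only by no change at the digits printed from compound 1 to compound 2 (within the scatter), so the propylsulfanyl and the butylamino substituent read alike here, and the loss of either of them coincides with the whole rise to compound 3.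

Compound 4 is `CCCNc1nc(N)c2nc(O)n(Cc3ccccc3)c2n1` and has not yet been measured in this assay. Relative to compound 3 the change is propylamino in place of hydrogen on an aromatic carbon. This is the reverse of the situation in the two measured steps: a chain returns to the aromatic carbon that is bare in compound 3, and the entering propylamino group is closest in kind to the butylamino group of compound 2.

On that basis compound 4 is expected to move far in the downward direction, with an estimated step of a 300-fold lower number from compound 3 to compound 4 (2.48 log units; beyond the scatter) in this assay. The expected value for compound 4 is 0.1 mg/kg, with a range estimated from 0.03 mg/kg to 0.3 mg/kg.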

Compound 4, minimum effective dose: 1 mg/kg
Beside the measured number, compound 4's estimate is 10-fold (1.00 log units) below it; measured number outside the range, above it.
By their numbers in this assay, from the lowest: compounds 1 and 2 (each within the scatter of the next); then compound 4; then compound 3.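

Returning a chain to the aromatic carbon between two ring nitrogen atoms recovers much of the effect in this assay, with a 30-fold lower number from compound 3 to compound 4 (1.48 log units; beyond the scatter), but not all of the distance to the two compounds with longer or sulfur-linked chains. Chain identity therefore matters at this position, which the matching values of compound 1 and compound 2 had hidden: removing a methyl from the chain end of the butylamino group gives a 10-fold higher number from compound 2 to compound 4 (1.00 log units; beyond the scatter), and propylamino in place of propylsulfanyl gives a 10-fold higher number from compound 1 to compound 4 (1.00 log units; beyond the scatter). Since compound 1 and compound 2 differ in both the linking atom and the chain, their match in this read-out does not show that either feature is without consequence, and nothing here explains the size of these steps.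

Going by these compounds, whether the number keeps falling with chain length or levels off at butylamino remains open, and a pentylamino group would address that. A butylsulfanyl group would show whether the sulfur link and the extra chain carbon act independently or overlap, and a propoxy group would extend the comparison of linking atoms.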